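Changing the aryl ether on a shared core

A few compounds are considered here, and "the series" means these few. Any claim that something is new, unique, unknown or untested is made for them only; others in the source may bear on it.

The compounds share one core, and the reported comparison turns on the aromatic ring attached to an oxygen on that core. Compound 1 `CCc1nn(C)c(CO/N=C/c2c(C)nn(C)c2Oc2cccc(Cl)c2)c1Cl` carries a 3-chlorophenyl there. In a functional assay on SMMC-7721 cells (Homo sapiens) for inhibition, read by MTT assay, with a stated time of 72 h, tested at 25 uM (a lower number here means less inhibition, a higher number more inhibition at the concentration tested (going by the name of the read-out)), compound 1 gives only a limit, < 80%, which is a limit of the assay and not a number (the limit of < 80% in this assay, at which 1 of the 3 values shown sits). Two relatives carry a 4-fluorophenyl on the core where compound 1 has ethyl. In this assay compound 2 `Cc1ccc(Oc2c(/C=N\OCc3c(Cl)c(-c4ccc(F)cc4)nn3C)c(C)nn2C)cc1` gives 80%, and compound 3 `COc1ccc(Oc2c(/C=N\OCc3c(Cl)c(-c4ccc(F)cc4)nn3C)c(C)nn2C)cc1` gives 80%. Among the measured compounds shown here, the only measured step, no change at the digits printed from compound 2 to compound 3 (within the scatter), touches the same ring and stays within the scatter.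

Compound 4 `CCc1nn(C)c(CO/N=C/c2c(C)nn(C)c2Oc2ccc(C)cc2)c1Cl` differs from compound 1 by 4-methylphenyl in place of 3-chlorophenyl on an oxygen on an aromatic ring. For the measured compounds named here, no measured step follows this exact change. The step from compound 2 to compound 3 is the nearest guide and was flat. Compound 2 and compound 4 share the 4-methylphenoxy but differ elsewhere on the core, so their values do not form a step. Compound 4 is therefore expected to sit near the limit, at an estimated 60% in this assay, within 30% to 85%. The step that the limit leaves unreadable from compound 1 to compound 4 is expected to be small, and a limit rather than a number may again be reported.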

Compound 4, a percentage reported as inhibition, at one concentration (the size of the read-out at that concentration, not a potency): < 80%
Compound 4: only a limit was reported; the forecaster's own chance of this, stated with the estimate: 50%; the middle value does not contradict the limit.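

In this assay compound 4 gives < 80%, a limit of the assay and not a number. Compound 1 also gives only a limit, so no step from compound 1 to compound 4 can be read: the limit of < 80% in this assay, at which 2 of the 4 values shown sit.

The compounds shown leave open how 3-chlorophenyl and 4-methylphenyl compare on the shared core in this assay.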